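The compounds below may be only part of what the source reports. "The series", "measured", "known", "first", "only" and "open" are said of these compounds alone.

Measured in a physicochemical assay for lipophilicity, read by HPLC, using the shake flask method, measured as octanol-water partition, at pH 7.4; a higher number here means a more lipophilic compound, a lower number a more polar compound:
- compound 1 `Cc1cc2ncccc2cc1Nc1ncc2c(n1)n(C1CCOCC1)c(=O)n2C` gives 2.5
- compound 2 `Cc1cc2nccnc2cc1Nc1ncc2c(n1)n(C1CCN(C)CC1)c(=O)n2C` gives 1.2
- compound 3 `Cc1cc2ncccc2cc1Nc1ncc2c(n1)n(C1CCNCC1)c(=O)n2C` gives 0.5

Compound 3 stands lowest of the three, and compound 2 lies nearest above it. Next comes compound 4 `Cc1cc2ncccc2cc1Nc1ncc2c(n1)n([C@H]1CCN(C)C1)c(=O)n2C`, with 1-methylpyrrolidin-3-yl in place of piperidin-4-yl on an aromatic nitrogen. Among the compounds with values here, no measured step isolates this exchange. Within the data shown here, the only measured step, a number 2.00 log units lower from compound 1 to compound 3 (beyond the scatter), is large but concerns piperidin-4-yl in place of oxan-4-yl. A smaller rise is expected, with compound 2 at 1.2 as the nearest reference. The estimated change is a number 0.60 log units higher from compound 3 to compound 4 (beyond the scatter) in this assay overall. Compound 4 is expected at 1.1, with an estimated range from 0.6 to 1.6 for repeat measurements.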

Compound 4, distribution coefficient: 1.1
Compound 4: middle estimate and measured number agree at the digits printed; low and high end bracket the measured number.
By their numbers in this assay, from the lowest: compound 3; then compounds 4 and 2 (each within the scatter of the next); then compound 1.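

In this assay, the exchange at this aromatic nitrogen gives a number 0.60 log units higher from compound 3 to compound 4 (beyond the scatter), so the read-out here also moves between two nitrogen-bearing rings of equal heavy-atom count, not only on leaving oxan-4-yl. Set against oxan-4-yl, 1-methylpyrrolidin-3-yl gives a number 1.40 log units lower from compound 1 to compound 4 (beyond the scatter), a smaller drop than a number 2.00 log units lower from compound 1 to compound 3 (beyond the scatter). Nothing available accounts for either new step.

As far as these compounds go, the exchange changes ring size and adds the methyl group on the ring nitrogen together, and which of the two carries the step stays open. 1-Methylpiperidin-4-yl or unmethylated pyrrolidin-3-yl on the core of compound 3 would separate them.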